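The source may hold more compounds than are shown below. What is called first, only, known or untested is meant among the compounds shown, and "the series" means these compounds.

Working notes on the series. Compound 1 `FC(F)(F)c1ccc(Cl)nc1N1CCN(Cc2nc3ccccc3n2Cc2ccccc2)CC1` is the starting point; in an assay on CHO cells with metabotropic glutamate receptor 2 (Homo sapiens) as the target, read by FLIPR (on this read-out higher numbers stand for an effect only at larger amounts of compound and lower numbers for an effect already at smaller amounts), compound 1 gives 126 nM. Compound 2 `COCCn1c(CN2CCN(c3nc(Cl)ccc3C(F)(F)F)CC2)nc2ccccc21` keeps the shared core and exchanges the arm on the ring nitrogen; in this assay compound 2 gives 158 nM. The only measured step, a 1.3-fold higher number from compound 1 to compound 2 (0.10 log units; within the scatter), lies within the scatter, so on the numbers shown compound 2 sits beside compound 1 with nothing beyond the scatter between them; two numbers only, no ordering possible.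

Compound 3 `FC(F)(F)c1ccc(Cl)nc1N1CCN(Cc2nc3ccccc3[nH]2)CC1` goes one step further: hydrogen in place of 2-methoxyethyl on an aromatic nitrogen. For the measured compounds named here, no measured step removes the arm from that ring nitrogen entirely. Going by the values given here, the single step that bears on the site, from compound 1 to compound 2, exchanged one arm for another and stayed within the scatter, which argues for a limited effect of the arm on this assay. Loss of the whole arm is a larger change than that exchange, so a modest rise cannot be excluded, but the expected step of a 1.4-fold higher number from compound 2 to compound 3 (0.14 log units; within the scatter) is small. Compound 3 is estimated at 220 nM, with a range from 70 nM to 700 nM.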

Compound 3, half-maximal effective concentration: 12600 nM
Compound 3: middle estimate off by 57-fold (1.76 log units), on the low side; the whole stated range lies below it.
By their numbers in this assay, from the lowest: compounds 1 and 2 (each within the scatter of the next); then compound 3.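

In this assay, the aromatic nitrogen of the shared core proves far less tolerant than the earlier exchange suggested: hydrogen in place of 2-methoxyethyl gives an 80-fold higher number from compound 2 to compound 3 (1.90 log units; beyond the scatter), and hydrogen in place of benzyl gives a 100-fold higher number from compound 1 to compound 3 (2.00 log units; beyond the scatter). The swap of one arm for the other, a 1.3-fold higher number from compound 1 to compound 2 (0.10 log units; within the scatter), stayed within the scatter and so could not show what these two steps show: the read-out is insensitive to which of these two arms is present, yet very sensitive to replacing either of them with hydrogen. Nothing available here accounts for the size of this change, so the finding remains purely an observation on the numbers.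

The compounds shown leave open how much of an arm is needed, since a methyl or ethyl group on this nitrogen could sit near compound 1 and compound 2 or near compound 3. They also leave open whether a longer chain, or an arm ending in an amine or a carboxylic acid, would hold the number at the level of compound 1 and compound 2.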